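The compounds below may be only part of what the source reports. "The series", "measured", "known", "first", "only" and "open" are said of these compounds alone.

In a functional assay on NCI-H460 cells (Homo sapiens) for inhibition, with a stated time of 72 h (on this read-out higher numbers stand for weaker inhibition and lower numbers for stronger inhibition), two compounds with the same core have been measured so far. Compound 1 (`COc1ccc(S(=O)(=O)N2CCc3cccc(-c4ccncc4)c32)cc1`) gives 101 nM, and compound 2 (`COc1ccc(S(=O)(=O)N2CCc3cccc(-c4cccnc4)c32)cc1`) gives 89.6 nM. Compound 2 therefore stands level with compound 1, and neither can be ranked above the other. The next structure is compound 3 (`COc1ccc(S(=O)(=O)N2CCc3cccc(-c4ccc(O)cc4)c32)cc1`), and the change is 4-hydroxyphenyl in place of pyridin-3-yl on an aromatic carbon. For the measured compounds named here, only one measured step bears on this change. That step, a 1.1-fold lower number from compound 1 to compound 2 (0.05 log units; within the scatter), exchanged pyridin-4-yl for pyridin-3-yl at the same place and did not move the number beyond the scatter. Going by the values given here, it shows that this place tolerated that one exchange, but it is a weak guide, since no measured compound carries a ring of carbon only or a hydroxy group there. A small step is therefore expected, with a slight lean towards a higher number and no firm expectation of a change beyond the scatter. The estimated step is a 1.6-fold higher number from compound 2 to compound 3 (0.19 log units; within the scatter). For compound 3 the estimated value is 140 nM, with an expected range of 40 nM to 500 nM.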

Compound 3, half-maximal inhibitory concentration: 114 nM
Beside the measured number, compound 3's estimate is 1.2-fold (0.09 log units) above it; low and high end bracket the measured number.
By their numbers in this assay, from the lowest: compounds 2, 1 and 3 (each within the scatter of the next).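

In this assay both a 1.3-fold higher number from compound 2 to compound 3 (0.10 log units; within the scatter) and a 1.1-fold higher number from compound 1 to compound 3 (0.05 log units; within the scatter) stay within the scatter, so all three compounds stand level and none can be ranked above another. Compound 3 is the only one of the three with a ring of carbon only at this place and the only one with a hydrogen-bond donor on that ring, so a ring nitrogen is not needed here for a number at this level, and this place accepts more than an exchange between pyridine isomers. Nothing measured independently accounts for how closely these numbers agree.

The change from pyridine to 4-hydroxyphenyl removes the ring nitrogen and adds the hydroxy group in one step, so only an unsubstituted phenyl at the same place could show whether either change has its own effect, or whether two effects happen to cancel. All three groups are six-membered aromatic rings, which leaves open how this place would respond to a saturated ring such as piperidine, a carboxylic acid, an amine or a longer alkyl chain.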